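Replacing the urea link with a simple benzamide

The source may hold more compounds than are shown below. What is called first, only, known or untested is meant among the compounds shown, and "the series" means these compounds.

Compound 2 `COc1cc(-c2nn(-c3cccc(NC(=O)Nc4ccc(Cl)c(C(F)(F)F)c4)c3)cc2-c2ccncc2)ccc1Cl` carries a urea joining the shared core to a chloro- and trifluoromethyl-bearing phenyl. Among the measured compounds shown here, in a functional assay on UACC-62 cells (Homo sapiens) for inhibition, read by sulforhodamine B assay, with a stated time of 48 h (on this read-out lower numbers stand for stronger inhibition of growth and higher numbers for weaker inhibition of growth), compound 2 gives 2090 nM, the highest of the two numbers so far, though its partner compound 1 `COc1cc(-c2nn(-c3cccc(NC(=O)Nc4cccc(C(F)(F)F)c4)c3)cc2-c2ccncc2)ccc1Cl` gives 1590 nM, and the step of a 1.3-fold higher number from compound 1 to compound 2 (0.12 log units; within the scatter) lies within the scatter. Compound 3 `COc1cc(-c2nn(-c3cccc(NC(=O)c4ccccc4)c3)cc2-c2ccncc2)ccc1Cl` is the unmeasured partner; here the change is phenyl in place of (4-chloro-3-(trifluoromethyl)phenyl)amino on a carbonyl carbon. For the measured compounds named here, the only measured step concerns that same outer ring, but it swapped a single substituent, whereas this change removes the whole aminoaryl portion together with its hydrogen-bond donor, so it offers little direct guidance. A modest weakening is therefore expected rather than known, with a wide range, giving an expected step of a 1.9-fold higher number from compound 2 to compound 3 (0.28 log units; within the scatter). For compound 3 the estimated result in this assay is 4000 nM, expected to fall between 1000 nM and 16000 nM.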

Compound 3, concentration for total growth inhibition: > 100000 nM
Compound 3 was reported as a limit; the forecaster's own chance of this, stated with the estimate: 10%; middle value at least 25-fold (1.39 log units) from the limit.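

In this assay, the earlier change on the outer ring, a 1.3-fold higher number from compound 1 to compound 2 (0.12 log units; within the scatter), said little about how much the group on this carbonyl carbon matters, whereas putting phenyl in place of the whole (4-chloro-3-(trifluoromethyl)phenyl)amino group gives an at least 47-fold higher number from compound 2 to compound 3 (1.67 log units; beyond the scatter), and the matching change from (3-(trifluoromethyl)phenyl)amino gives an at least 62-fold higher number from compound 1 to compound 3 (1.79 log units; beyond the scatter). Growth inhibition at this position therefore survives a chloro swap on the outer ring but not the change from urea to simple benzamide. The value for compound 3 is a limit of the assay, not a number: the limit of > 100000 nM in this assay, at which 1 of the 3 values shown sits.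

As far as these compounds go, the amide-type nitrogen and the ring substituents leave together in these steps, so their separate contributions remain unknown. A plain phenylamino group on the carbonyl carbon would keep the urea without those substituents, while a 3-(trifluoromethyl)phenyl ring placed directly on that carbon would keep a substituent without the urea.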